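Ester chain changes and microsomal half-life in the series

This account rests on a few compounds, and the source may have more. Where it says the series, first, only, none or still open, it means among the compounds named here.

Measured compounds:
Compound 1 `CCOc1cc(NC(=O)C2(NC(=O)c3ccc4c(C5CCCC5)c(-c5ncc(Cl)cn5)n(C)c4c3)CCC2)ccc1/C=C/C(=O)OC(=O)C[C@H](O)C(=O)O` gives in an ADME assay (liver) for pharmacokinetics, with Liver microsome (Homo sapiens) as the target, using microsomes (a higher number here means that the compound lasts longer, a lower number that the compound disappears faster), a value of 5.57 h.
Compound 2 `CCOC(=O)/C=C/c1ccc(NC(=O)C2(NC(=O)c3ccc4c(C5CCCC5)c(-c5ncc(Cl)cn5)n(C)c4c3)CCC2)cc1OCC` gives in this assay only a limit of the assay, > 5 h.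
Compound 3 `CCCCCCOC(=O)/C=C/c1ccc(NC(=O)C2(NC(=O)c3ccc4c(C5CCCC5)c(-c5ncc(Cl)cn5)n(C)c4c3)CCC2)cc1OCC` gives in this assay a value of 17.9 h.

Compound 3 holds the highest of the two numbers seen so far; the nearest is compound 1, and the step of a 3.2-fold higher number from compound 1 to compound 3 (0.51 log units; beyond the scatter) separates them, with hexyl in place of (2-carboxy-2-hydroxyethyl)carbonyl on an oxygen next to a carbonyl group. The step that the limit leaves unreadable from compound 2 to compound 3, butyl in place of hydrogen on a saturated chain carbon two bonds along the chain from an oxygen next to a carbonyl group, cannot be sized because of the limit of > 5 h in this assay, at which 1 of the 3 values shown sits. The same holds for a step that the limit leaves unreadable from compound 1 to compound 2.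

Compound 4 `CCOc1cc(NC(=O)C2(NC(=O)c3ccc4c(C5CCCC5)c(-c5ncc(Cl)cn5)n(C)c4c3)CCC2)ccc1/C=C/C(=O)OCC(Cl)(Cl)Cl` differs from compound 3 by trichloromethyl in place of pentyl on a saturated chain carbon bound to an oxygen next to a carbonyl group. Going by the values given here, both readable and unreadable steps so far alter this ester chain only; the single readable one is modest, and the change from hexyl to ethyl is hidden behind the limit. Compound 4 removes most of the hexyl chain, so a modest fall is expected, the step of a 2.2-fold lower number from compound 3 to compound 4 (0.35 log units; beyond the scatter) being the estimate. For compound 4 in this assay the expected value is 8 h, within an estimated range of 3 h to 20 h.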

Compound 4, half-life: > 5 h
Compound 4: no number, only a limit; the forecaster's own chance of this, stated with the estimate: 20%; the middle value does not contradict the limit.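

In this assay compound 4 gives only a limit of the assay, > 5 h, not a number. No step between compound 4 and compound 1, compound 2 or compound 3 can therefore be read, because of this limit: the limit of > 5 h in this assay, at which 2 of the 4 values shown sit.

The compounds shown leave open where the 2,2,2-trichloroethyl chain of compound 4 stands relative to the ethyl chain of compound 2 and the hexyl chain of compound 3.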